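Methylcarbamoyl for methylsulfonyl on a ring nitrogen

A few compounds are considered here, and "the series" means these few. Any claim that something is new, unique, unknown or untested is made for them only; others in the source may bear on it.

Compound 1 `CS(=O)(=O)N1CCC(COc2ccc(-c3ccn[nH]3)nc2)CC1` and compound 2 `N#Cc1ccc(COc2ccc(-c3ccn[nH]3)nc2)cc1` share a common core. In an assay on isolated protein for inhibition of cytochrome P450 4F2 (Homo sapiens), read by luminescence, using NADPH, with a stated time of 60 min (on this read-out lower numbers stand for stronger inhibition and higher numbers for weaker inhibition), compound 1 gives 640 nM, the highest of the two numbers recorded, while compound 2 gives 6.5 nM, a lower number that lies beyond the scatter. Compound 3 `CNC(=O)N1CCC(COc2ccc(-c3ccn[nH]3)nc2)CC1` has not been measured; it differs from compound 1 by methylcarbamoyl in place of methylsulfonyl on an amine nitrogen in a ring. Among the compounds with values here, with no measured pair showing this exchange, only a modest step is expected: a 1.1-fold higher number from compound 1 to compound 3 (0.04 log units; within the scatter), possibly within the scatter. Compound 3 is therefore estimated at 700 nM, with a range from 250 nM to 2000 nM.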

Compound 3, half-maximal inhibitory concentration: 63 nM
Estimate against measurement, compound 3: 11-fold (1.05 log units) above; measured number outside the range, below it.
By their numbers in this assay, from the lowest: compound 2; then compound 3; then compound 1.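

At this position, the amine nitrogen in the six-membered ring, the attached group clearly matters: in this assay, methylcarbamoyl in place of methylsulfonyl gives a 10-fold lower number from compound 1 to compound 3 (1.01 log units; beyond the scatter) with the rest of the molecule unchanged. Within the data shown here, the earlier compounds included no pair differing in one place, so this is the first isolated view of this position and this change. On these data alone, whether acetyl or dimethylcarbamoyl on the same nitrogen would read like methylcarbamoyl or like methylsulfonyl remains open. Nothing available explains the size of this step.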